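The compounds below may be only part of what the source reports. "The series", "measured", "known", "first", "only" and "open" are said of these compounds alone.

Among the compounds with values here, in a functional assay on MDA-MB-231 cells (Homo sapiens) for antiproliferative activity, read by MTT assay, with a stated time of 72 h (a higher number here means a weaker inhibitor, a lower number a stronger inhibitor), compound 3 `Cc1ccc(NC(=O)c2ccc(Cl)c(C(F)(F)F)c2)cc1C#Cc1nn(C[C@H](C)CO)c2ncnc(N)c12` gives 17 nM, the lowest of the three numbers measured so far, though within the scatter of both neighbours: compound 2 `Cc1ccc(NC(=O)c2ccc(Cl)c(C(F)(F)F)c2)cc1C#Cc1nn(C[C@@H](C)CO)c2ncnc(N)c12` gives 23 nM and compound 1 `Cc1ccc(NC(=O)c2cccc(C(C)(C)C)c2)cc1C#Cc1nn([C@H]2CC[C@H](O)CC2)c2ncnc(N)c12` gives 30 nM. Within the data shown here, the only single-point step measured, a 1.4-fold lower number from compound 2 to compound 3 (0.13 log units; within the scatter), rests on (the fact that compounds 2 and 3 differ only in the configuration as drawn). Compound 4 `Cc1ccc(NC(=O)c2ccc(Cl)c(C(F)(F)F)c2)cc1C#Cc1nn([C@H]2CC[C@H](O)CC2)c2ncnc(N)c12` has not yet been measured; it carries 4-hydroxycyclohexyl in place of 2-(hydroxymethyl)propyl on an aromatic nitrogen. Among the measured compounds shown here, no measured step isolates that change. For the measured compounds named here, compound 1 already bears the 4-hydroxycyclohexyl group but differs from compound 3 elsewhere as well, so its value shows only that this group can sit alongside a similar number. Compound 4 is therefore expected to stay in the same range, with a step of a 1.2-fold higher number from compound 3 to compound 4 (0.07 log units; within the scatter) no larger than the scatter. The estimate for compound 4 is 20 nM, between 8 nM and 50 nM.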

Compound 4, half-maximal inhibitory concentration: 16 nM
The estimate for compound 4 lay 1.3-fold (0.10 log units) above the measured number; the range from low to high includes it.
By their numbers in this assay, from the lowest: compounds 4, 3, 2 and 1 (each within the scatter of the next).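

With the 4-chloro-3-(trifluoromethyl)phenyl group held, 4-hydroxycyclohexyl in place of 2-(hydroxymethyl)propyl on the aromatic nitrogen can now be read directly in this assay, and the steps of a 1.1-fold lower number from compound 3 to compound 4 (0.03 log units; within the scatter) and a 1.4-fold lower number from compound 2 to compound 4 (0.16 log units; within the scatter) show that this position takes the ring as well as the open chain. With 4-hydroxycyclohexyl held, 4-chloro-3-(trifluoromethyl)phenyl in place of 3-(tert-butyl)phenyl on the carbonyl carbon gives a 1.9-fold lower number from compound 1 to compound 4 (0.27 log units; within the scatter) and so also stays within the scatter. Nothing at hand explains these steps. Going by these compounds, whether an amine or a carboxylic acid in place of the hydroxyl, or a longer chain on the aromatic nitrogen, would keep the number in this range remains open.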